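A Ring Swap on Compound 3

This account rests on a few compounds, and the source may have more. Where it says the series, first, only, none or still open, it means among the compounds named here.

Of the compounds shown here, three have been tested in a physicochemical assay for solubility, using the shake flask method, in phosphate buffer, measured as kinetic solubility, with a stated time of 20 h, at pH 6.5; on this read-out higher numbers stand for higher solubility and lower numbers for lower solubility. Compound 1 `FC(F)(F)c1cccc(-c2nc3cnc(Nc4ccncn4)cc3[nH]2)c1` returned only a limit of the assay, < 5000 nM. Compound 2 `Fc1ccc(Nc2cc3[nH]c(-c4ccc(F)c(F)c4)nc3cn2)nc1` also returned only a limit, < 5000 nM. Within the data shown here, compound 3 `FC(F)(F)c1ccc(Nc2cc3[nH]c(C4CCCC4)nc3cn2)nc1` gives 145000 nM, the only actual number so far. Compound 4 `FC1(F)CC(c2nc3cnc(Nc4ccc(C(F)(F)F)cn4)cc3[nH]2)C1` carries 3,3-difluorocyclobutyl in place of cyclopentyl on an aromatic carbon. Each of these groups is a non-aromatic ring of carbon only. Among the measured compounds shown here, no measured pair shows what such a swap does, so the expectation rests on compound 3 alone, at 145000 nM. The expected step, a 1.2-fold lower number from compound 3 to compound 4 (0.08 log units; within the scatter), stays within the usual scatter of this assay. Compound 4 is estimated at 120000 nM, with an expected range of 40000 nM to 300000 nM.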

Compound 4, solubility: 118000 nM
Compound 4: middle estimate off by 1.0-fold (0.01 log units), on the high side, and the stated range covers the measured number.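

Among these compounds, putting 3,3-difluorocyclobutyl in place of cyclopentyl, on the aromatic carbon between two ring nitrogen atoms, gives the first one-place comparison in this assay: a 1.2-fold lower number from compound 3 to compound 4 (0.09 log units; within the scatter). Two different non-aromatic rings of carbon only can therefore sit at this position with values that cannot be told apart. The remaining compounds offer no such comparison, only a limit of the assay: the limit of < 5000 nM in this assay, at which 2 of the 4 values shown sit.

This single pair covers carbon-only rings alone. As far as these compounds go, how an amine, a carboxylic acid or a longer chain at this position would read remains open.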